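This account rests on a few compounds, and the source may have more. Where it says the series, first, only, none or still open, it means among the compounds named here.

Compound 1 `COc1ccc(Cc2nnc3n2N=C(c2ccc(Cl)cc2)CS3)cc1` and compound 2 `COc1ccc(Cc2nnc3n2N=C(c2ccc(F)cc2)CS3)cc1` share one core and differ in a single place: fluoro in place of chloro on an aromatic carbon. In a functional assay on the whole organism (strain BALB/c) with Mus musculus as the target, in the writhing test, with a stated time of 1 h, at a dose of 100 mg/kg by the oral route (on this read-out higher numbers stand for a stronger effect at the one dose given and lower numbers for a weaker effect), compound 1 gives 33%, and compound 2 gives 26.3%, so the step reads a number 6.7 percentage points lower from compound 1 to compound 2 (within the scatter). Compound 3 `COc1ccc(CCc2nnc3n2N=C(c2ccc(Cl)cc2)CS3)cc1` is built on a second core; how this core differs from the core of compound 1 is not broken down here. In this assay compound 3 gives 71.5%, the highest of the three numbers, with its steps to compound 1 and to compound 2 both beyond the scatter. Compound 4 `COc1ccc(CCc2nnc3n2N=C(c2ccc(F)cc2)CS3)cc1` is the one not yet measured. It differs from compound 3 in one place: fluoro in place of chloro on an aromatic carbon. This is the same change as from compound 1 to compound 2, at the same place, and it occurs twice among the compounds shown. The step from compound 3 to compound 4 is expected to be small, a number 7.5 percentage points lower from compound 3 to compound 4 (within the scatter), because the earlier step of a number 6.7 percentage points lower from compound 1 to compound 2 (within the scatter) stayed within the scatter. For compound 4 in this assay the estimate is 64%, expected to fall between 50% and 78%.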

Compound 4, a percentage reported as inhibition, in the whole organism at one dose (the size of the read-out at that dose, not a potency): 29.2%
Beside the measured number, compound 4's estimate is 34.8 percentage points above it; measured number outside the range, below it.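

On the second core, fluoro in place of chloro on the aromatic carbon gives a large step in this assay, a number 42.3 percentage points lower from compound 3 to compound 4 (beyond the scatter), so the small step on the first core cannot be used to predict the size of this change on the second. The same change therefore does not carry over at the same size between these two cores: the same change on two cores in this assay, a number 6.7 percentage points lower (within the scatter) from compound 1 to compound 2 and a number 42.3 percentage points lower (beyond the scatter) from compound 3 to compound 4, 35.6 percentage points apart, beyond the scatter of two such steps

This shows that, in this series, the size of the change from 4-chlorophenyl to 4-fluorophenyl depends on the core, but two pairs give no general rule, do not explain the gap and say nothing about any further core.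

Only chloro and fluoro are shown on this aromatic carbon, so the effect of bromo or trifluoromethyl there remains open, as does the effect of a longer chain in place of the one in compound 3. Each compound is also read at a single dose, which shows only a stronger or weaker effect at that dose and leaves open how the compounds compare at any other dose.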